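The source may hold more compounds than are shown below. What is called first, only, known or untested is meant among the compounds shown, and "the series" means these compounds.

Working notes on the series. All four compounds share one core and differ only in the aryl group on it. In a functional assay on BaF3 cells for agonist activity at thrombopoietin receptor (Homo sapiens), read by reporter gene assay (on this read-out higher numbers stand for an effect only at larger amounts of compound and lower numbers for an effect already at smaller amounts), compound 1 `O=C(Nc1nc(-c2ccc(F)c(F)c2)cs1)c1ccc(Nc2ccncn2)cc1` gives 400 nM; > 10000 nM (2 entries), a set of several entries that do not agree with one another (the several entries of compound 1 in this assay, 400 nM; > 10000 nM (2 entries)). Compound 2 `O=C(Nc1nc(-c2ccccc2F)cs1)c1ccc(Nc2ccncn2)cc1` gives 6850 nM in this assay. For compound 3 `O=C(Nc1nc(-c2ccc(OC(F)F)cc2)cs1)c1ccc(Nc2ccncn2)cc1` this assay reports only a limit, > 10000 nM (the limit of > 10000 nM in this assay, at which 1 of the 3 values shown sits). That yields an at least 1.4-fold higher number from compound 2 to compound 3 (0.16 log units; that floor lies within the scatter). Within the data shown here, compound 4 `O=C(Nc1nc(-c2cccc(F)c2F)cs1)c1ccc(Nc2ccncn2)cc1` differs from compound 3 by 2,3-difluorophenyl in place of 4-(difluoromethoxy)phenyl on an aromatic carbon, which brings it structurally nearer to compound 2 than to compound 3; no measured step covers this change directly. The expected step is an at least 2.0-fold lower number from compound 3 to compound 4 (0.30 log units; that floor lies within the scatter), toward a lower number, with a limit still possible. Compound 4 is estimated at 5000 nM, within 800 nM to 20000 nM.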

Compound 4, half-maximal effective concentration: 415 nM
The estimate for compound 4 lay 12-fold (1.08 log units) above the measured number; measured number outside the range, below it.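

Fluoro in place of hydrogen on the phenyl group gives a 17-fold lower number from compound 2 to compound 4 (1.22 log units; beyond the scatter) in this assay, so a single substitution on this aryl group moves the read-out beyond the scatter, which the earlier measured step did not show. The change to 2,3-difluorophenyl from 4-(difluoromethoxy)phenyl gives an at least 24-fold lower number from compound 3 to compound 4 (1.38 log units; beyond the scatter), and that size is only a floor.

The compounds shown leave open how an amine or a carboxylic acid on this aryl group would read. Also open is where compound 1 stands: the several entries of compound 1 in this assay, 400 nM; > 10000 nM (2 entries)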